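The source may hold more compounds than are shown below. What is called first, only, known or untested is meant among the compounds shown, and "the series" means these compounds.

Within the data shown here, in a physicochemical assay for solubility, in phosphate buffer, with a stated time of 18 h, at pH 7.4 (on this read-out lower numbers stand for lower solubility and higher numbers for higher solubility), compound 2 `COc1cc2ncnc(-n3nc(-c4ccccn4)nc3N)c2cc1OCc1ccccc1` gives 58000 nM, the second highest of the three numbers measured so far. Compound 3 `COc1cc2c(-n3nc(-c4ccccn4)nc3N)ncnc2cc1OCc1ccccc1` gives 68000 nM and compound 1 `CCOC(=O)CNc1nc(-n2nc(-c3ccccn3)nc2N)c2cc(OC)c(OC)cc2n1` gives 48000 nM; each differs from compound 2 by less than the usual scatter, so no order among the three is claimed. Compound 4 `CCCCCCOC(=O)NCCCOc1cc2c(-n3nc(-c4ccccn4)nc3N)ncnc2cc1OC` has not yet been measured. It differs from compound 2 by 2-((hexyloxycarbonyl)amino)ethyl in place of phenyl on a saturated chain carbon bound to an oxygen on an aromatic ring. Among the measured compounds shown here, no step between measured compounds is available to calibrate a change of this kind, and the three measured numbers span a narrow range. In this assay the step from compound 2 to compound 4 is expected to be small, in either direction, or none beyond the scatter. Compound 4 is estimated at 40000 nM, within a range of 12000 nM to 130000 nM. The expected step is a 1.5-fold lower number from compound 2 to compound 4 (0.16 log units; within the scatter).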

Compound 4, solubility: 1000 nM
Compound 4: the middle estimate sits 40-fold (1.60 log units) above what was measured; the measured number lies below the stated range.
By their numbers in this assay, from the lowest: compound 4; then compounds 1, 2 and 3 (each within the scatter of the next).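

In this assay, the place on a saturated chain carbon bound to an oxygen on an aromatic ring can carry a large change: 2-((hexyloxycarbonyl)amino)ethyl in place of phenyl gives a 58-fold lower number from compound 2 to compound 4 (1.76 log units; beyond the scatter), the only step shown. Compounds 1, 2 and 3 lie within the scatter of one another and gave no sign of a drop this size. No measurement shown bears on the cause of this step.

The compounds shown do not separate the loss of phenyl from the entry of the hexyloxycarbonyl part. From the compounds shown here alone, how a shorter alkyl chain, an amine or a carboxylic acid would read at this place remains open.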